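Expected cytotoxicity of a dimethoxyphenyl analogue

This account rests on a few compounds, and the source may have more. Where it says the series, first, only, none or still open, it means among the compounds named here.

In an ADME assay on MT4 cells (Homo sapiens) for cytotoxicity, read by MTT assay (on this read-out lower numbers stand for higher toxicity in this test and higher numbers for lower toxicity in this test), compound 1 `O=C(CSc1nnnn1-c1cccc2ccccc12)N/N=C/c1cccs1` gives > 316000 nM, which is a limit of the test rather than a number. Compound 2 `O=C(CSc1nnnn1-c1cccc2ccccc12)N/N=C/c1ccc(F)cc1` likewise gives > 307000 nM, also a limit. Compound 3 `Cc1cccc(/C=N/NC(=O)CSc2nnnn2-c2cccc3ccccc23)c1` gives 269000 nM. The step of an at least 1.1-fold lower number from compound 1 to compound 3 (0.06 log units; that floor lies within the scatter) and the step of an at least 1.1-fold lower number from compound 2 to compound 3 (0.05 log units; that floor lies within the scatter) both stay within the scatter, while the step that the two limits leave unreadable from compound 1 to compound 2 cannot be read. Compound 4 `COc1cccc(/C=N/NC(=O)CSc2nnnn2-c2cccc3ccccc23)c1OC` differs from compound 1 by 2,3-dimethoxyphenyl in place of thiophen-2-yl on a carbon with a double bond to nitrogen. Among the measured compounds shown here, the only measured steps that bear on this change swap the same group for 3-methylphenyl, and they moved nothing beyond the scatter, so no shift beyond the scatter is expected for an at least 1.1-fold lower number from compound 1 to compound 4 (0.05 log units; that floor lies within the scatter), in either direction. Compound 4 is therefore estimated at 280000 nM in this assay, between 150000 nM and 500000 nM.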

Compound 4, half-maximal cytotoxic concentration: 192000 nM
Estimate against measurement, compound 4: 1.5-fold (0.16 log units) above; low and high end bracket the measured number.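

Among the compounds shown here, compound 4 places 2,3-dimethoxyphenyl, with more heavy atoms and hydrogen-bond acceptors than thiophen-2-yl, on the carbon with a double bond to nitrogen, and the one step in this assay between two exact values is a 1.4-fold lower number from compound 3 to compound 4 (0.15 log units; within the scatter). The other two steps are an at least 1.6-fold lower number from compound 1 to compound 4 (0.21 log units; that floor lies within the scatter) and an at least 1.5-fold lower number from compound 2 to compound 4 (0.20 log units; that floor lies within the scatter). Each starts from a limit, so the true gap could be larger than its floor.

Nothing shown explains why the values fall where they do. From the compounds shown here alone, whether an amine or a carboxylic acid at this place would give a step beyond the scatter remains open.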